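Aryl substituent change on the enone series: compound 4

The source may hold more compounds than are shown below. What is called first, only, known or untested is meant among the compounds shown, and "the series" means these compounds.

Compound 1, `COc1cccc(/C=C/C(=O)c2ccc(OC)c3c2OC(C)(C)C=C3)c1`: in a functional assay on HepG2 cells (Homo sapiens) for antiproliferative activity, read by MTT assay, with a stated time of 24 h (a lower number here means a stronger inhibitor, a higher number a weaker inhibitor), compound 1 gives only a limit, > 10000 nM.
Compound 2, `COc1ccc(/C=C/C(=O)c2ccc(OC)c3c2OC(C)(C)C=C3)c(F)c1`: in this assay compound 2 gives 7560 nM.
Compound 3, `COc1ccc(C(=O)/C=C/c2ccc(N(C)C)cc2)c2c1C=CC(C)(C)O2`: in this assay compound 3 gives 730 nM.

Among these, compound 3 holds the lowest of the two actual numbers, with compound 2 nearest; compound 1 sits at the assay limit (the limit of > 10000 nM in this assay, at which 1 of the 3 values shown sits). Both measured steps that reach compound 3 concern the aryl group on the double-bonded chain carbon: an at least 13-fold lower number from compound 1 to compound 3 (1.13 log units; beyond the scatter) and a 10-fold lower number from compound 2 to compound 3 (1.02 log units; beyond the scatter), each a large move in the same direction.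

Compound 4 is `COc1ccc(C(=O)/C=C/c2ccc(-n3ccnc3)cc2)c2c1C=CC(C)(C)O2`. Relative to compound 3 the change is 1H-imidazol-1-yl in place of dimethylamino on an aromatic carbon. For the measured compounds named here, no measured step involves an imidazolyl group, so the direction rests only on the observation that swapping the aryl substituent at this position has shifted the number strongly in the two steps above; leaving the dimethylamino group that marks the lowest number is expected to cost potency, a 2.7-fold higher number from compound 3 to compound 4 (0.44 log units; beyond the scatter). Compound 4 is estimated at 2000 nM, in the range 600 nM to 7000 nM.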

Compound 4, half-maximal inhibitory concentration: > 10000 nM
Compound 4 was reported as a limit; the forecaster's own chance of this, stated with the estimate: 10%; middle value at least 5.0-fold (0.69 log units) away from the limit.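

In this assay, replacing dimethylamino with 1H-imidazol-1-yl on the same aromatic carbon gives an at least 13-fold higher number from compound 3 to compound 4 (1.13 log units; beyond the scatter). The earlier steps shown here exchanged whole aryl groups, whereas this one keeps the enone and the phenyl ring and changes only the substituent para to a large group, which is enough to lose the low number of compound 3, so a nitrogen-linked substituent here does not by itself secure it. Compound 4 gives only a limit, so the full size of the step stays unknown, and it now shares that limit with compound 1: the limit of > 10000 nM in this assay, at which 2 of the 4 values shown sit.

Still open, from the compounds shown here alone, is whether the low number of compound 3 is specific to dimethylamino or extends to other amines, such as diethylamino, pyrrolidin-1-yl or morpholin-4-yl. Going by these compounds, it is also open whether a primary amine at this carbon would keep it.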